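One Small Swap Tried on Two Related Cores

A few compounds are considered here, and "the series" means these few. Any claim that something is new, unique, unknown or untested is made for them only; others in the source may bear on it.

Compound 1 `CCOC(=O)c1c(-c2c(Cl)c3cc(C)ccc3oc2=O)nn(-c2cccc(C)c2)c1C(=O)OCC` and compound 2 `CCOC(=O)c1c(-c2c(Cl)c3cc(C)ccc3oc2=O)nn(-c2cccc(Cl)c2)c1C(=O)OCC` share one core and differ only by chloro in place of methyl on an aromatic carbon. In a functional assay on DU-145 cells (Homo sapiens) for cytotoxicity, read by MTT assay, with a stated time of 48 h (a higher number here means a weaker inhibitor, a lower number a stronger inhibitor), compound 1 gives 103000 nM and compound 2 gives 156000 nM, a step of a 1.5-fold higher number from compound 1 to compound 2 (0.18 log units; within the scatter). Compound 3 `CCOC(=O)c1c(-c2cc3ccc(OC)cc3oc2=O)nn(-c2cccc(C)c2)c1C(=O)OCC` is built on a different core; the difference between the two cores is not broken down here. In this assay compound 3 gives 35000 nM, the lowest number among the three measured compounds. Compound 4 `CCOC(=O)c1c(-c2cc3ccc(OC)cc3oc2=O)nn(-c2cccc(Cl)c2)c1C(=O)OCC` has not yet been measured; it differs from compound 3 by chloro in place of methyl on an aromatic carbon, the same change already made between compound 1 and compound 2, at the same place. Because that earlier step was a 1.5-fold higher number from compound 1 to compound 2 (0.18 log units; within the scatter), for compound 4 a similarly small step is expected, a 1.5-fold higher number from compound 3 to compound 4 (0.17 log units; within the scatter). Compound 4 is therefore estimated at 52000 nM, with a likely range from 25000 nM to 110000 nM.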

Compound 4, half-maximal inhibitory concentration: 38000 nM
Estimate against measurement, compound 4: 1.4-fold (0.14 log units) above; low and high end bracket the measured number.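

In this assay, replacing 3-methylphenyl with 3-chlorophenyl on the second core gives a 1.1-fold higher number from compound 3 to compound 4 (0.04 log units; within the scatter). Set beside the earlier step, the swap carries over between the two cores without a difference that can be told from the scatter: the same change on two cores in this assay, a 1.5-fold higher number (0.18 log units; within the scatter) from compound 1 to compound 2 and a 1.1-fold higher number (0.04 log units; within the scatter) from compound 3 to compound 4, 1.4-fold (0.14 log units) apart, within the scatter of two such steps. This shows that the swap changed little on either core, but two pairs cannot show that the same would hold on other cores or for other swaps.

As far as these compounds go, it remains open whether a different group at the same place on the ring, such as an amine, a carboxylic acid or a longer chain, would move the number beyond the scatter. Behaviour in other cell lines also remains open.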